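The source may report more compounds than this note shows. Statements on the series, on what has been measured and on what is new or still open speak of the compounds shown alone.

For the measured compounds named here, in a functional assay on HeLa cells (Homo sapiens) for inhibition, read by sulforhodamine B assay, with a stated time of 74 h (a higher number here means a weaker inhibitor, a lower number a stronger inhibitor), compound 1 (`CS(=O)(=O)N1C(=O)COC12C=CC(=O)C=C2`) gives 7530 nM as the higher of the two numbers measured so far. Compound 2 (`COc1ccc(S(=O)(=O)N2C(=O)COC23C=CC(=O)C=C3)cc1`) gives 880 nM in this assay with a gap beyond the usual scatter of repeat measurements, which makes compound 1 the weaker inhibitor of this pair. Compound 3 (`O=C1C=CC2(C=C1)OCC(=O)N2S(=O)(=O)c1cccs1`) has not yet been measured. It has thiophen-2-yl in place of methyl on a sulfonyl sulfur and otherwise keeps the core of compound 1. Going by the values given here, compound 2 also carries an aromatic ring on that sulfur and reaches 880 nM in this assay as the only guide, so the support is thin. The expected change is a 6.3-fold lower number from compound 1 to compound 3 (0.80 log units; beyond the scatter) in the direction of stronger inhibition and beyond the scatter. Compound 3 is estimated at 1200 nM with an expected range from 350 nM to 4000 nM in this measurement.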

Compound 3, half-maximal inhibitory concentration: 3420 nM
Compound 3: middle estimate off by 2.9-fold (0.45 log units), on the low side, within the range that was stated.
By their numbers in this assay, from the lowest: compound 2; then compound 3; then compound 1.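

In this assay the change from methyl to thiophen-2-yl on a sulfonyl sulfur gives a 2.2-fold lower number from compound 1 to compound 3 (0.34 log units; beyond the scatter) and so is a modest gain, though one beyond the scatter of repeat measurements. An aromatic ring on this sulfur therefore now goes with stronger inhibition than methyl in two compounds, but the ring matters: compound 3 at 3420 nM is weaker than compound 2 at 880 nM. Nothing measured here explains the gain or the gap between the two aromatic groups.

Going by these compounds, it remains open how a plain phenyl ring, a longer chain such as n-butyl, or a ring carrying an amine or a carboxylic acid would behave on this sulfur. The compounds shown also say nothing about changes elsewhere on the shared core.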